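Refilling a stripped chain carbon with an isopropyl branch

A few compounds are considered here, and "the series" means these few. Any claim that something is new, unique, unknown or untested is made for them only; others in the source may bear on it.

In a functional assay on the whole organism (Tail, strain ICR) with Mus musculus as the target, in the tail flick test, with a stated time of 60 min, at a dose of 25 umol/kg by the oral route (on this read-out lower numbers stand for a weaker effect and higher numbers for a stronger effect at the one dose given), compound 1 `N=C(N)NCCC[C@H](NC(=O)CN(c1nc(Cl)nc2[nH]cnc12)C1CC1)C(=O)O` gives 51%, while compound 2 `O=C(O)CNC(=O)CN(c1nc(Cl)nc2[nH]cnc12)C1CC1` gives 38.9%, the lower of the two numbers. For the measured compounds named here, the one step measured, a number 12.1 percentage points lower from compound 1 to compound 2 (beyond the scatter), shows that losing the larger group at this spot cost a modest amount. Compound 3 `CC(C)[C@H](NC(=O)CN(c1nc(Cl)nc2[nH]cnc12)C1CC1)C(=O)O` differs from compound 2 by isopropyl in place of hydrogen on a saturated chain carbon bound to an amide-type nitrogen and a carbonyl carbon. The earlier step bears on the same place, so a gain at most modest is expected. For compound 3 the step of a number 6.1 percentage points higher from compound 2 to compound 3 (within the scatter) is estimated to be small, near the scatter. Compound 3 is therefore expected to give 45%, within 30% to 60%.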

Compound 3, a percentage reported as activity, at one dose (the size of the read-out at that dose, not a potency): 38.8%
Compound 3: the middle estimate sits 6.2 percentage points above what was measured; low and high end bracket the measured number.
By their numbers in this assay, from the lowest: compounds 3 and 2 (each within the scatter of the next); then compound 1.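

In this assay, isopropyl on this saturated chain carbon does no more than hydrogen, with the change staying within the scatter (a number 0.1 percentage points lower from compound 2 to compound 3 (within the scatter)). Size alone as a branch therefore gives no gain here, while the group of 7 heavy atoms in compound 1 still holds a modest lead over isopropyl (a number 12.2 percentage points lower from compound 1 to compound 3 (beyond the scatter)). Nothing measured here explains this difference. Which part of that larger group matters stays open. A shorter chain ending in an amine, or a phenyl ring at this carbon, could show whether a group other than that larger one recovers the effect.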